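The source may hold more compounds than are shown below. What is called first, only, known or untested is meant among the compounds shown, and "the series" means these compounds.

Working notes on the series.

Of the compounds shown here, two have been measured in a functional assay on DLA cells (Mus musculus) for cytotoxicity, read by trypan blue exclusion, with a stated time of 48 h; a lower number here means a stronger inhibitor, a higher number a weaker inhibitor. Compound 1 `Cc1cc(C(=O)c2ccccc2)ccc1OCC(=O)Nc1nc(-c2ccccc2)cs1` gives 21500 nM and is the lowest of the two numbers. Compound 2 `Cc1cc(C(=O)c2ccc(F)cc2)ccc1OCC(=O)Nc1nc(-c2ccccc2)cs1` gives 32100 nM. Within the data shown here, the one step measured so far, from compound 1 to compound 2, is a 1.5-fold higher number from compound 1 to compound 2 (0.17 log units; within the scatter); the change there is a fluoro in place of a hydrogen on an aromatic carbon of the benzoyl ring, and the two numbers therefore cannot be told apart.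

Compound 3 `Cc1cc(C(=O)c2ccccc2)cc(C)c1OCC(=O)Nc1nc(-c2ccccc2)cs1` is not yet measured in this assay. It differs from compound 1 by methyl in place of hydrogen on an aromatic carbon: a methyl in place of a hydrogen on an aromatic carbon of a six-membered aromatic ring of carbon only, ortho to a large group, meta to the benzoyl group and meta to the existing methyl group. Among the measured compounds shown here, no measured step touches this ring or this kind of change, so the measured step from compound 1 to compound 2 bears on it only in showing that the series has, so far, moved within the scatter. The expected step from compound 1 to compound 3 is a 1.1-fold lower number from compound 1 to compound 3 (0.03 log units; within the scatter), that is, no shift beyond the scatter. On that basis compound 3 is expected to give about 20000 nM in this assay, with a range from 8000 nM to 50000 nM.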

Compound 3, half-maximal inhibitory concentration: 19100 nM
For compound 3 the middle estimate is 1.0-fold (0.02 log units) above the measured one, and the stated range covers the measured number.
By their numbers in this assay, from the lowest: compounds 3, 1 and 2 (each within the scatter of the next).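

The step to compound 3 is the only measured one on this ring: a methyl in place of a hydrogen on an aromatic carbon, ortho to a large group, meta to a benzoyl group and meta to a methyl group. In this assay it gives a 1.1-fold lower number from compound 1 to compound 3 (0.05 log units; within the scatter), so this position accepts the methyl without a shift that can be told from the scatter, and the earlier fluoro step on the benzoyl ring could not show that for this ring. No measurement at hand accounts for this result, and none gives a property of the methyl group at this position.

As far as these compounds go, whether another group at this position, such as a methoxy group, an amine, a carboxylic acid or a longer chain such as ethyl, would give a number beyond the scatter stays open. Both steps shown lie within the scatter, so they leave open whether any single change on either ring can move the number in this assay at all.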